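The source may report more compounds than this note shows. Statements on the series, on what has been measured and on what is new or still open speak of the compounds shown alone.

Measured compounds in a functional assay on the whole organism (strain Wistar) for inhibition, with Rattus norvegicus as the target, read by paw edema, with a stated time of 30 min, at a dose of 50 mg/kg by the oral route; a lower number here means less inhibition, a higher number more inhibition at the dose given (going by the name of the read-out):
compound 1 `CC(=O)N1N=C(c2ccc(C)cc2)CC1c1cn(-c2ccccc2)nc1-c1ccc(Cl)c(Cl)c1`, 27.7%
compound 2 `Cc1ccc(C2=NNC(c3cn(-c4ccccc4)nc3-c3ccc(Cl)c(Cl)c3)C2)cc1`, 38.3%
compound 3 `CC(=O)N1N=C(c2ccc(Cl)cc2)CC1c1cn(-c2ccccc2)nc1-c1ccc(Cl)c(Cl)c1`, 45.7%

Compound 4 `Clc1ccc(C2=NNC(c3cn(-c4ccccc4)nc3-c3ccc(Cl)c(Cl)c3)C2)cc1` is not yet measured. From compound 1 to compound 2 the change is hydrogen in place of acetyl on an amine nitrogen in a ring, and the step was a number 10.6 percentage points higher from compound 1 to compound 2 (beyond the scatter). The change from compound 3 to compound 4 is hydrogen in place of acetyl on an amine nitrogen in a ring, the same kind of change, though not the same: in compound 1 the ring atom two ring bonds away bears a 4-methylphenyl group, in compound 3 a 4-chlorophenyl group. The two cores differ by chloro in place of methyl on an aromatic carbon, which gave a number 18 percentage points higher from compound 1 to compound 3 (beyond the scatter). Compound 3 stands highest of the three measured numbers, though compound 2 sits within the scatter of it.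

For compound 4 a step of about a number 9.3 percentage points higher from compound 3 to compound 4 (within the scatter) is expected, beside the earlier one, resting on the step of a number 10.6 percentage points higher from compound 1 to compound 2 (beyond the scatter) on the other core. Compound 4 is therefore estimated at 55%, with an expected range from 42% to 68%.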

Compound 4, a percentage reported as inhibition, in the whole organism at one dose (the size of the read-out at that dose, not a potency): 33%
The estimate for compound 4 lay 22 percentage points above the measured number; measured number outside the range, below it.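

In this assay, hydrogen in place of acetyl on an amine nitrogen in a ring gives a number 12.7 percentage points lower from compound 3 to compound 4 (beyond the scatter), so the step seen on the core of compound 1 does not carry over to the core of compound 3: the same change on two cores in this assay, a number 10.6 percentage points higher (beyond the scatter) from compound 1 to compound 2 and a number 12.7 percentage points lower (beyond the scatter) from compound 3 to compound 4, 23.3 percentage points apart, beyond the scatter of two such steps. Chloro in place of methyl on an aromatic carbon likewise depends on the core, giving a number 5.3 percentage points lower from compound 2 to compound 4 (within the scatter) once the acetyl is gone: the same change on two cores in this assay, a number 18 percentage points higher (beyond the scatter) from compound 1 to compound 3 and a number 5.3 percentage points lower (within the scatter) from compound 2 to compound 4, 23.3 percentage points apart, beyond the scatter of two such steps. Across these four compounds neither change behaves as a fixed increment that can be moved between cores, but they do not show what lies behind this or how it extends to other groups.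

Open, as far as these compounds go, is how a formyl or propionyl group on the same ring nitrogen would behave. Also open, from the compounds shown here alone, is whether a 4-fluorophenyl or 4-methoxyphenyl group would show the same dependence on the acetyl group.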